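A few compounds are considered here, and "the series" means these few. Any claim that something is new, unique, unknown or untested is made for them only; others in the source may bear on it.

In a functional assay on MCF7 cells (Homo sapiens) for cytotoxicity, read by MTT assay, with a stated time of 72 h (a higher number here means a weaker inhibitor, a lower number a stronger inhibitor), compound 1 (`O=C(N/N=C/c1cccc(Cl)c1Cl)Nc1cc2c(Nc3ccc(F)c(Cl)c3)ncnc2cc1O[C@H]1CCOC1`) is reported as "not active" (no number reported) and has no single number. Compound 2 (`COc1ccc(/C=N/NC(=O)Nc2cc3c(Nc4ccc(F)c(Cl)c4)ncnc3cc2O[C@H]2CCOC2)c(OC)c1OC`) gives 33800 nM and compound 3 (`O=C(N/N=C/c1cc(Br)c(O)c(Br)c1)Nc1cc2c(Nc3ccc(F)c(Cl)c3)ncnc2cc1O[C@H]1CCOC1`) gives 5910 nM there. Compound 4 (`COc1cc2ncnc(Nc3ccc(F)c(Cl)c3)c2cc1NC(=O)N/N=C/c1cccc(Cl)c1Cl`) carries methyl in place of oxolan-3-yl on an oxygen on an aromatic ring. Within the data shown here, the only measured step, a 5.7-fold lower number from compound 2 to compound 3 (0.76 log units; beyond the scatter), changes a different group and keeps the oxolan-3-yl in place, so it does not bear on this change. With no number for compound 1, no size or direction of step in this assay can be derived, and none beyond the scatter is expected. Compound 4 is estimated at 20000 nM within an expected range from 5000 nM to 70000 nM in this read-out.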

Compound 4, half-maximal inhibitory concentration: 28700 nM
Estimate against measurement, compound 4: 1.4-fold (0.16 log units) below; low and high end bracket the measured number.
By their numbers in this assay, from the lowest: compound 3; then compounds 4 and 2 (each within the scatter of the next).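

Among these compounds, compound 1 has no number in this assay, so no step to compound 4 can be read. The compounds shown leave open what methyl in place of oxolan-3-yl does to the number in this assay here. No supporting measurement bears on this result.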